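Trimming Isopropyl to Methyl on the Shared Core

The source may hold more compounds than are shown below. What is called first, only, known or untested is meant among the compounds shown, and "the series" means these compounds.

This account starts from two compounds, compound 1 (`Cn1c(/C=C2/C(=O)Nc3ccc([N+](=O)[O-])cc32)nc2ccccc21`) and compound 2 (`CC(C)n1c(/C=C2/C(=O)Nc3ccc(Cl)cc32)nc2ccccc21`). In a functional assay on HGC cells (Homo sapiens) for cytotoxicity, read by MTT assay, with a stated time of 48 h (a lower number here means a stronger inhibitor, a higher number a weaker inhibitor), compound 1 has the entry "not determined" (no result reported) and so provides no number. Within the data shown here, compound 2 gives 32800 nM as the only number available, which leaves it with no measured neighbour for comparison. Compound 3 (`Cn1c(/C=C2/C(=O)Nc3ccc(Cl)cc32)nc2ccccc21`) keeps the core of compound 2 but carries methyl in place of isopropyl on an aromatic nitrogen. Among the measured compounds shown here, no measured pair shows what such a change does, so the expectation rests on compound 2 at 32800 nM alone. No step beyond the scatter is expected in this assay, and neither direction is favoured. The expected change is small, with a 1.1-fold lower number from compound 2 to compound 3 (0.04 log units; within the scatter) as the estimated step. For compound 3 the estimate is 30000 nM with an expected range from 12000 nM to 75000 nM in this measurement.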

Compound 3, half-maximal inhibitory concentration: 43600 nM
Beside the measured number, compound 3's estimate is 1.5-fold (0.16 log units) below it; the range from low to high includes it.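

In this assay, among these compounds, the move from isopropyl to methyl on an aromatic nitrogen now has a measured step, a 1.3-fold higher number from compound 2 to compound 3 (0.12 log units; within the scatter), the first number for any change at this position. On the shared core, then, this nitrogen accepts either methyl or isopropyl with no step beyond the scatter, and the change gives no sign of a preferred direction. No supporting measurement bears on this result, and it offers no explanation for it.

Going by these compounds, compound 1 has no number, so steps involving it cannot be read, and the effect of nitro in place of chloro on the shared core stays open. Also open, on these data alone, is whether a longer chain, or a chain ending in an amine or a carboxylic acid, on this nitrogen would give a step beyond the scatter.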